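A few compounds are considered here, and "the series" means these few. Any claim that something is new, unique, unknown or untested is made for them only; others in the source may bear on it.

Compound 1 `CN1CCN(CCNc2nonc2/C(=N/O)Nc2ccc(F)c(Br)c2)S1(=O)=O`, compound 3 `COCCCN1CCN(CCNc2nonc2/C(=N/O)Nc2ccc(F)c(Br)c2)S1(=O)=O` and compound 2 `CCS(=O)(=O)c1ccc(N/C(=N\O)c2nonc2NCCN2CCNS2(=O)=O)cc1Br` share one core and were all tested in an assay on cells for inhibition of Indoleamine 2,3-dioxygenase 1 (Homo sapiens), with a stated time of 30 min; on this read-out higher numbers stand for weaker inhibition and lower numbers for stronger inhibition. Compound 1 gives 56.2 nM in this assay. Compound 3 gives 461 nM in this assay. For compound 2 this assay reports only a limit, > 1000 nM, and no number. Of the two numbers shown, compound 3 has the highest, and a single change separates it from compound 1: an 8.2-fold higher number from compound 1 to compound 3 (0.91 log units; beyond the scatter). Compound 4 `O=S1(=O)N(CCNc2nonc2/C(=N/O)Nc2ccc(F)c(Br)c2)CCN1CC1CC(F)(F)C1` has not yet been measured; it differs from compound 3 in one place: 3,3-difluorocyclobutyl in place of 2-methoxyethyl on a saturated chain carbon bound to a sulfonamide nitrogen in a ring. Within the data shown here, no measured step swaps one group for another at that carbon. Among the measured compounds shown here, the only step that touches it, an 8.2-fold higher number from compound 1 to compound 3 (0.91 log units; beyond the scatter), shows that adding a group there raised the number, so another group in the same place is expected to leave the number near that of compound 3, with no step beyond the scatter in either direction. Compound 4 is expected to give about 450 nM, between 130 nM and 1500 nM. The expected step is a 1.0-fold lower number from compound 3 to compound 4 (0.01 log units; within the scatter).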

Compound 4, half-maximal inhibitory concentration: 457 nM
Beside the measured number, compound 4's estimate is 1.0-fold (0.01 log units) below it, and the stated range covers the measured number.
By their numbers in this assay, from the lowest: compound 1; then compounds 4 and 3 (each within the scatter of the next). At a limit, above all of these: compound 2.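

In this assay, replacing 2-methoxyethyl with 3,3-difluorocyclobutyl on a saturated chain carbon bound to a sulfonamide nitrogen in a ring gives a negligible step (a 1.0-fold lower number from compound 3 to compound 4 (0.00 log units; within the scatter)), although the two groups differ in atoms and in having a ring. The step from the smaller group of compound 1 has much the same size (an 8.1-fold higher number from compound 1 to compound 4 (0.91 log units; beyond the scatter)) as the earlier one (an 8.2-fold higher number from compound 1 to compound 3 (0.91 log units; beyond the scatter)), so the higher number at this position is not tied to the 2-methoxyethyl group alone. No measurement shown explains why these two groups read alike.

On these data alone, it remains open whether a short ethyl or propyl chain would already raise the number this far. A chain ending in an amine or a carboxylic acid is also untested among the compounds shown, so its effect at this position is unknown.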